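The source may report more compounds than this note shows. Statements on the series, on what has been measured and on what is new or still open speak of the compounds shown alone.

Compound 1 `CC1CCN(C2CCN(S(=O)(=O)c3ccc(-c4ccccc4)cc3)CC2)CC1` gives > 5000 nM in an ADME assay on HCT-116 cells (Homo sapiens) for cytotoxicity, read by CellTiter-Glo, with a stated time of 72 h (a higher number here means a weaker inhibitor, a lower number a stronger inhibitor), and that reading is a limit of the assay, not a number. Compound 2 `COc1ccc(-c2ccc(S(=O)(=O)N3CCC(N4CCC(C)CC4)CC3)cc2)cc1` gives > 5000 nM in this assay and that reading is also only a limit. Compound 2 therefore has no exact place on the scale, and the whole record so far is the limit of > 5000 nM in this assay, at which 2 of the 2 values shown sit, as its summary. Within the data shown here, the one measured step is a step that the two limits leave unreadable from compound 1 to compound 2 and so offers no size to carry forward.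

Compound 3 `CC1CCN(C2CCN(S(=O)(=O)c3ccc(C(C)(C)C)cc3)CC2)CC1` has not yet been measured. It differs from compound 2 by tert-butyl in place of 4-methoxyphenyl on an aromatic carbon in one place, with tert-butyl in place of 4-methoxyphenyl on an aromatic carbon. Among the measured compounds shown here, no measured step covers this exchange, so the data give no size or direction for it, and no clear move is expected in this assay. The expectation rests on compound 2 at > 5000 nM as a limit, and compound 3 is expected to stay in that region. The expected step is a step that the limit leaves unreadable from compound 2 to compound 3 as an estimate only. For compound 3 the estimate is 8000 nM with an expected range of 3000 nM to 20000 nM and a reading that will probably be a limit again.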

Compound 3, half-maximal inhibitory concentration: > 5000 nM
Compound 3: only a limit was reported (the forecaster's own chance of this, stated with the estimate: 85%); the middle value lies beyond the limit too.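

Compound 3 also reads as a limit, so none of the steps among compound 1, compound 2 and compound 3 can be read, and they offer no size or direction. The record remains a single reading: the limit of > 5000 nM in this assay, at which 3 of the 3 values shown sit.

The compounds shown leave open whether any of them truly differs from the others in this assay, and which change on the aromatic ring, if any, would give a measurable value.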